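The source may report more compounds than this note shows. Statements on the series, on what has been measured and on what is new or still open speak of the compounds shown alone.

Three compounds have been measured so far in an assay on microsomes for inhibition of acyl-CoA:cholesterol acyltransferase (Oryctolagus cuniculus); on this read-out lower numbers stand for stronger inhibition and higher numbers for weaker inhibition:

compound 1 `Cc1ccc(C2(CNC(=O)Nc3c(C(C)C)cccc3C(C)C)CCCC2)cc1` gives 25 nM
compound 2 `CC(C)c1cccc(C(C)C)c1NC(=O)NCC1(c2ccc(F)cc2)CCCC1` gives 23 nM
compound 3 `CC(C)c1cccc(C(C)C)c1NC(=O)NCC1(c2cccc(OCc3ccccc3)c2)CCCC1` gives 30 nM

Among these three numbers compound 1 stands second highest in this assay; compound 2 is its nearest neighbour and compound 3 its furthest, and neither separation goes beyond the scatter of the measurement. Within the data shown here, the one measured step between neighbours, a 1.1-fold lower number from compound 1 to compound 2 (0.04 log units; within the scatter), exchanged a substituent on the aromatic ring attached to the saturated ring carbon and moved the number by nothing beyond the scatter. Compound 3, which carries a much larger substituent on that aromatic ring, also sits close to compound 1.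

Compound 4 `COC(=O)c1cccc(C2(CNC(=O)Nc3c(C(C)C)cccc3C(C)C)CCCC2)c1` differs from compound 1 at the same place: 3-(methoxycarbonyl)phenyl in place of 4-methylphenyl on a saturated ring carbon. Among the measured compounds shown here, the only steps that bear on this change are those just described, and both show that varying the substituent on this aromatic ring has so far left this assay essentially unchanged. A small step is therefore expected, a 1.4-fold higher number from compound 1 to compound 4 (0.15 log units; within the scatter), with at most a slight drift toward a higher number. For compound 4 the estimate in this assay is 35 nM, within a range from 15 nM to 90 nM.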

Compound 4, half-maximal inhibitory concentration: 34 nM
Beside the measured number, compound 4's estimate is 1.0-fold (0.01 log units) above it, within the range that was stated.
By their numbers in this assay, from the lowest: compounds 2, 1, 3 and 4 (each within the scatter of the next).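

In this assay, the exchange that brings in 3-(methoxycarbonyl)phenyl, with its two hydrogen-bond acceptors, in place of 4-methylphenyl, which has none, on a saturated ring carbon gives a 1.4-fold higher number from compound 1 to compound 4 (0.13 log units; within the scatter). The other comparisons agree, with a 1.5-fold higher number from compound 2 to compound 4 (0.17 log units; within the scatter) for the exchange of 4-fluorophenyl and a 1.1-fold higher number from compound 3 to compound 4 (0.05 log units; within the scatter) for methoxycarbonyl in place of benzyloxy on an aromatic carbon, so the set of substituents at this place now extends to a carbonyl-bearing ester without any step to compound 4 leaving the scatter. No measurement is available that accounts for this flat picture.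

The compounds shown leave open whether a carboxylic acid or a primary amine in place of the methoxycarbonyl group would stay equally close in this assay, since all four compounds carry no net charge at this place. Every compound also keeps the rest of the core of compound 1 unchanged, so these numbers say nothing about how a change elsewhere in the core would read.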